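Methyl for chloro on the amide-bearing phenyl ring

The source may hold more compounds than are shown below. What is called first, only, known or untested is meant among the compounds shown, and "the series" means these compounds.

Three compounds share a core and were tested in a functional assay on the whole organism (strain Wistar albino) for inhibition, with Rattus norvegicus as the target, read by paw edema, with stated times of 1 h and 2 h, at a dose of 40 mg/kg by the oral route; a lower number here means less inhibition, a higher number more inhibition at the dose given (going by the name of the read-out). Compound 3 `Cc1nc(Cc2ccc(Cl)cc2)sc1C1SCC(=O)N1c1ccc(Cl)cc1` gives 40.1%, compound 1 `Cc1ccc(N2C(=O)CSC2c2sc(Cc3ccc(Cl)cc3)nc2C)cc1` gives 61.4%, and compound 2 `Cc1nc(-c2ccc(Cl)cc2)sc1C1SCC(=O)N1c1ccc(Cl)cc1` gives 45.7%. The change methyl in place of chloro on an aromatic carbon gives a number 21.3 percentage points higher from compound 3 to compound 1 (beyond the scatter). The cores of compound 3 and compound 2 differ by 4-chlorophenyl in place of 4-chlorobenzyl on an aromatic carbon, and that step is a number 5.6 percentage points lower from compound 2 to compound 3 (within the scatter). Compound 4 `Cc1ccc(N2C(=O)CSC2c2sc(-c3ccc(Cl)cc3)nc2C)cc1` is not yet measured; it arises from compound 2 by methyl in place of chloro on an aromatic carbon, the same change as from compound 3 to compound 1, made on the core of compound 2 instead. Because a number 21.3 percentage points higher from compound 3 to compound 1 (beyond the scatter) was seen once, a step of similar size is expected, namely a number 19.3 percentage points higher from compound 2 to compound 4 (beyond the scatter). Compound 4 is therefore estimated at 65% in this assay, between 52% and 78%; with one precedent only, the expectation is uncertain.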

Compound 4, a percentage reported as inhibition, in the whole organism at one dose (the size of the read-out at that dose, not a potency): 37.6%
Estimate against measurement, compound 4: 27.4 percentage points above; measured number below the stated range.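

On the core of compound 2, methyl in place of chloro gives a number 8.1 percentage points lower from compound 2 to compound 4 (within the scatter) in this assay, so the gain seen on the other core does not carry over: the same change on two cores in this assay, a number 21.3 percentage points higher (beyond the scatter) from compound 3 to compound 1 and a number 8.1 percentage points lower (within the scatter) from compound 2 to compound 4, 29.4 percentage points apart, beyond the scatter of two such steps

Seen from the other side, 4-chlorophenyl in place of 4-chlorobenzyl gives a number 23.8 percentage points lower from compound 1 to compound 4 (beyond the scatter), so the outcome of one change depends on the group present at the other place: the same change on two cores in this assay, a number 5.6 percentage points lower (within the scatter) from compound 2 to compound 3 and a number 23.8 percentage points higher (beyond the scatter) from compound 4 to compound 1, 29.4 percentage points apart, beyond the scatter of two such steps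

These four compounds show that the two changes do not simply add up, but they do not show why.

They leave open what other groups would do in place of that chloro or methyl, such as a methoxy group, a fluoro group or an amine. From the compounds shown here alone, whether the same dependence holds on further cores also stays open.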